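Triazole hydroxamic acids: isoquinolinyl replaced by trifluoromethylphenyl

The compounds below may be only part of what the source reports. "The series", "measured", "known", "first", "only" and "open" are said of these compounds alone.

Measured so far in an assay on Sf9 cells for inhibition of protein deacetylase HDAC6 (Homo sapiens), read by fluorescence, with a stated time of 40 min, tested at 100 nM; a higher number here means more inhibition at the concentration tested (going by the name of the read-out), a lower number less inhibition:
compound 1, `O=C(NO)c1ccc(NCc2nc(-c3cccc4cnccc34)nn2-c2ccccc2)cc1`, gives 40.2%
compound 2, `Cc1ccc(-n2nc(-c3ccccc3)nc2CNc2ccc(C(=O)NO)cc2)cc1`, gives 60.7%
compound 3, `NC(=O)c1ccc(NCc2nc(-c3ccccc3)nn2-c2ccccc2)cc1`, gives -4.4%

Compound 1 stands second highest of the three. Compound 2 sits higher by a margin beyond the scatter, and compound 3, the only one without a hydroxamic acid, sits lowest, again beyond the scatter. Within the data shown here, no measured pair differs in a single place, so no step size is known directly.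

Compound 4, `O=C(NO)c1ccc(NCc2nc(-c3ccc(C(F)(F)F)cc3)nn2-c2ccccc2)cc1`, is not yet measured. It differs from compound 1 in one place: 4-(trifluoromethyl)phenyl in place of isoquinolin-5-yl on an aromatic carbon. The hydroxamic acid and the shared core are kept. The step of a number 7.8 percentage points higher from compound 1 to compound 4 (within the scatter) is expected to be small, upward if anything, and likely within the scatter. Compound 4 is estimated at 48%, with a range from 25% to 70%.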

Compound 4, a percentage reported as inhibition, at one concentration (the size of the read-out at that concentration, not a potency): 41.6%
Estimate against measurement, compound 4: 6.4 percentage points above, and the stated range covers the measured number.
By their numbers in this assay, from the lowest: compound 3; then compounds 1 and 4 (each within the scatter of the next); then compound 2.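

In this assay, 4-(trifluoromethyl)phenyl in place of isoquinolin-5-yl gives a number 1.4 percentage points higher from compound 1 to compound 4 (within the scatter), the first step read directly at this aromatic carbon of the five-membered ring. At this concentration, the read-out therefore does not depend on the ring nitrogen of isoquinolin-5-yl, the hydrogen-bond acceptor counted in that group. No measured property is at hand to account for this result. Still open, from the compounds shown here alone, is how an amine or a carboxylic acid in place of the trifluoromethyl group would read. A single-concentration percentage also leaves potency unsettled.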